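Furan-3-yl for ethynyl on two related nucleoside cores

The source may report more compounds than this note shows. Statements on the series, on what has been measured and on what is new or still open speak of the compounds shown alone.

Compound 1 `C#Cc1cn([C@@H]2O[C@H](CO)[C@@H](O)[C@H]2O)c2ncnc(C)c12` and compound 2 `Cc1ncnc2c1c(-c1ccoc1)cn2[C@@H]1O[C@H](CO)[C@@H](O)[C@H]1O` share one core; compound 3 `C#Cc1cn([C@@H]2O[C@H](CO)[C@@H](O)[C@H]2O)c2nc(N)nc(OC)c12` and the not yet measured compound 4 `COc1nc(N)nc2c1c(-c1ccoc1)cn2[C@@H]1O[C@H](CO)[C@@H](O)[C@H]1O` share another. The difference between the two cores is not broken down here.

In a functional assay on K562 cells (Homo sapiens), read by MTT assay, with a stated time of 72 h (on this read-out higher numbers stand for weaker inhibition and lower numbers for stronger inhibition), compound 1 gives 6920 nM. Compound 2 reaches only the limit of this assay, > 20000 nM. Compound 3 likewise reaches only the limit of this assay, > 20000 nM. In this assay the step is an at least 2.8-fold higher number from compound 1 to compound 2 (0.46 log units; beyond the scatter), and the change behind it is furan-3-yl in place of ethynyl on an aromatic carbon. That this step carries only a bound and no full number is due to the limit of > 20000 nM in this assay, at which 2 of the 3 values shown sit.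

Compound 4 carries the same change on the core of compound 3: furan-3-yl in place of ethynyl on an aromatic carbon. The place of the change reads the same, word for word, for both pairs, so this is the same change made on two cores. The pair compound 3 to compound 4 is not measured; only the first pair shows its direction, and that direction is toward weaker inhibition.

Compound 3 already sits at the limit of this assay, and the change on the first core gave a higher number, so compound 4 is expected to sit at that limit as well. The estimate for compound 4 in this assay is 50000 nM, with an expected range from 20000 nM to 150000 nM. The step this estimate means is expected to be a step that the limit leaves unreadable from compound 3 to compound 4, resting on the measured pair compound 1 to compound 2.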

Compound 4, half-maximal inhibitory concentration: > 20000 nM
Compound 4: a limit, no number (the forecaster's own chance of this, stated with the estimate: 95%); the middle value does not contradict the limit.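

In this assay compound 4 gives > 20000 nM, which is a limit and not a number. Compound 3 also sits at a limit, so no step can be read from compound 3 to compound 4, due to one shared bound: the limit of > 20000 nM in this assay, at which 3 of the 4 values shown sit.

The compounds shown leave open whether furan-3-yl in place of ethynyl on an aromatic carbon changes inhibition at all on the core of compound 3.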